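Swapping a benzylsulfanyl group for ethoxy on a triazole-type core

The compounds below may be only part of what the source reports. "The series", "measured", "known", "first", "only" and "open" are said of these compounds alone.

Of the compounds shown here, two have been measured so far. Compound 1 `CCCSc1nnc(Cc2ccc(Cl)cc2Oc2ccccc2Cl)[nH]1` carries a propylsulfanyl group on its shared core, and in a functional assay on the whole organism (strain NMRI) with Mus musculus as the target, with a stated time of 60 min, at a dose of 20 mg/kg by the intraperitoneal route (on this read-out lower numbers stand for a weaker effect and higher numbers for a stronger effect at the one dose given), compound 1 gives 134%. Compound 2 `Clc1ccc(Cc2nnc(SCc3ccccc3)[nH]2)c(Oc2ccccc2Cl)c1` differs only by a phenyl in place of ethyl on a saturated chain carbon bound to a sulfur, and in this assay compound 2 gives 129%. The step of a number 5 percentage points lower from compound 1 to compound 2 (within the scatter) is within the scatter, so the two numbers cannot be put in order; compound 2 simply stands next to compound 1 with a value that is not distinguishable from it.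

Compound 3 `CCOc1nnc(Cc2ccc(Cl)cc2Oc2ccccc2Cl)[nH]1` is the next compound. Its change from compound 2 is ethoxy in place of benzylsulfanyl on an aromatic carbon. Among the measured compounds shown here, no measured step touches this change: the one step known, from compound 1 to compound 2, altered only the chain on the sulfur and left the attachment through sulfur in place, and it was within the scatter. With nothing pointing in either direction, the expected step of a number 4 percentage points lower from compound 2 to compound 3 (within the scatter) is put at no change beyond the scatter, with a wide range to allow for the unknown. Compound 3 is therefore estimated at 125%, expected to fall between 90% and 150%.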

Compound 3, a percentage reported as activity, at one dose (the size of the read-out at that dose, not a potency): 135%
Compound 3: the middle estimate sits 10 percentage points below what was measured; the measured number falls inside the stated range.
By their numbers in this assay, from the lowest: compounds 2, 1 and 3 (each within the scatter of the next).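

The earlier pair changed only the chain on the sulfur, whereas this result replaces the sulfur link itself with an oxygen link on the aromatic carbon between two ring nitrogen atoms. In this assay, ethoxy in place of benzylsulfanyl gives a number 6 percentage points higher from compound 2 to compound 3 (within the scatter) and ethoxy in place of propylsulfanyl gives a number 1 percentage points higher from compound 1 to compound 3 (within the scatter), so across these three compounds neither the change of linking atom nor the loss of the six-membered aromatic ring, with the group shrinking from 8 heavy atoms to 3, separates the numbers at this one dose. No supporting evidence is available to explain this lack of separation.

The three compounds leave open whether a group of a different kind at this position, such as an amine or a carboxylic acid, or a longer chain on the oxygen, would give a number that stands clear of the scatter. A reading at a single dose also leaves open whether the three compounds would still look alike at lower doses or at times other than the one stated.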